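Swapping the aryl substituent on a piperazine succinimide propanamide

The source may hold more compounds than are shown below. What is called first, only, known or untested is meant among the compounds shown, and "the series" means these compounds.

Measured compounds:
- compound 1, `CC(C(=O)N1CCN(c2ccc(C(F)(F)F)cc2)CC1)N1C(=O)CCC1=O`, 25%
- compound 2, `CC(C(=O)N1CCN(c2ccc(F)cc2)CC1)N1C(=O)CCC1=O`, 100%

Both were tested in a functional assay on the whole organism (strain Swiss) with Mus musculus as the target, in the maximal electroshock model, with a stated time of 0.25 h, at a dose of 300 mg/kg by the intraperitoneal route; on this read-out higher numbers stand for a stronger effect at the one dose given and lower numbers for a weaker effect. Compound 2 stands highest of the two numbers: its nearest neighbour, compound 1, lies far lower, as shown by the step of a number 75 percentage points higher from compound 1 to compound 2 (beyond the scatter).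

Compound 3, `Cc1cccc(N2CCN(C(=O)C(C)N3C(=O)CCC3=O)CC2)c1`, has not yet been tested. Relative to compound 2 the change is 3-methylphenyl in place of 4-fluorophenyl on an amine nitrogen in a ring. For the measured compounds named here, no measured step covers this particular swap; the single known step concerns a change at the same ring and was large, so this region of the molecule clearly matters to the read-out. Since compound 2 sits at the top of the scale, a further rise cannot be seen, and a drop of some size is the more likely outcome.

Compound 3 is therefore expected to give 75%, within 25% to 100%, which would mean an expected step of a number 25 percentage points lower from compound 2 to compound 3 (beyond the scatter).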

Compound 3, a percentage reported as activity, at one dose (the size of the read-out at that dose, not a potency): 100%
Estimate against measurement, compound 3: 25 percentage points below, and the stated range covers the measured number.
By their numbers in this assay, from the lowest: compound 1; then compounds 2 and 3 (each within the scatter of the next).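

In this assay, the earlier step of a number 75 percentage points higher from compound 1 to compound 2 (beyond the scatter) showed that the group on this ring nitrogen can matter greatly, but replacing 4-fluorophenyl with 3-methylphenyl gives no change at the digits printed from compound 2 to compound 3 (within the scatter), so not every change here costs activity. A fluorine on the aromatic ring is therefore not needed for the full effect at this dose, although a read-out at one dose cannot show how the effects of compound 2 and compound 3 would compare at other doses. Nothing shown here explains why these two groups give the same number.

Going by these compounds, it remains open whether an unsubstituted phenyl, a 4-methoxyphenyl or a 3-chlorophenyl group would keep the effect. Tests at lower doses could also show whether compound 2 and compound 3 stay level once the read-out falls below the top of its scale.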